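Swapping the carboxyphenyl arm for a benzofurazan

This account rests on a few compounds, and the source may have more. Where it says the series, first, only, none or still open, it means among the compounds named here.

Compound 1: `O=C(O)c1cncc(CN2CCC[C@H](O[C@H](CO)c3cc(Cl)cc(Cl)c3)[C@@H]2c2ccccc2)c1`, 28000 nM
Compound 2: `OC[C@@H](O[C@H]1CCCN(Cc2ncc[nH]2)[C@H]1c1ccccc1)c1cc(Cl)cc(Cl)c1`, 8800 nM
Compound 3: `O=C(O)c1ccc(CN2CCC[C@H](O[C@H](CO)c3cc(Cl)cc(Cl)c3)[C@@H]2c2ccccc2)cc1`, 15000 nM

These three compounds share one core and differ only in the aromatic group attached to a saturated chain carbon bound to an amine nitrogen in a ring. In an assay on HEK293 cells for activation of cGMP-dependent protein kinase 1 (Homo sapiens), read by HTRF, with a stated time of 3 h (on this read-out higher numbers stand for an effect only at larger amounts of compound and lower numbers for an effect already at smaller amounts), compound 3 sits second highest of the three numbers; its gaps to the other two (a 1.7-fold higher number from compound 2 to compound 3 (0.23 log units; within the scatter) and a 1.9-fold lower number from compound 1 to compound 3 (0.27 log units; within the scatter)) both stay within the scatter, so the three cannot be ordered with confidence. Only the change a 3.2-fold lower number from compound 1 to compound 2 (0.50 log units; beyond the scatter) reaches beyond the scatter, and that one is modest.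

Compound 4 is `OC[C@@H](O[C@H]1CCCN(Cc2cccc3nonc23)[C@H]1c1ccccc1)c1cc(Cl)cc(Cl)c1`. Relative to compound 3 the change is a group of 9 heavy atoms (6 carbon, 2 nitrogen, 1 oxygen; one five-membered aromatic ring with 3 hetero atoms, one six-membered aromatic ring of carbon only) in place of a group of 9 heavy atoms (7 carbon, 2 oxygen; one six-membered aromatic ring of carbon only), on a saturated chain carbon bound to an amine nitrogen in a ring. The steps already seen at this position are the ones that bear on it, and they moved the number little. The expectation is therefore a step of a 1.3-fold lower number from compound 3 to compound 4 (0.10 log units; within the scatter), with no confident direction. Compound 4 is estimated at 12000 nM in this assay, within a range from 4000 nM to 40000 nM.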

Compound 4, half-maximal effective concentration: 141000 nM
Estimate against measurement, compound 4: 12-fold (1.07 log units) below; measured number outside the range, above it.
By their numbers in this assay, from the lowest: compounds 2, 3 and 1 (each within the scatter of the next, the first and the last beyond it); then compound 4.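

Until now, changing the aromatic group on this saturated chain carbon bound to an amine nitrogen in a ring had moved the number only modestly, but the benzofurazan shows that this position does not accept every group. In this assay it gives a 9.4-fold higher number from compound 3 to compound 4 (0.97 log units; beyond the scatter) and a 5.0-fold higher number from compound 1 to compound 4 (0.70 log units; beyond the scatter) and also a 16-fold higher number from compound 2 to compound 4 (1.20 log units; beyond the scatter) in one change, leaving compound 4 with the highest number of the four, beyond the scatter of each of the others. Heavy-atom count alone does not set the number, since the benzofurazan and 4-carboxyphenyl both hold 9 heavy atoms, and dropping the carboxylic acid does not by itself raise it, since compound 2 has none and lies within the scatter of compound 3.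

Going by these compounds, whether a plain phenyl or a phenyl carrying an amine would sit with compound 2 and compound 3 or with compound 4 stays open. Nothing measured here accounts for the jump.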